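From Chloropyridinyl Amide to Cyanophenyl Amide

A few compounds are considered here, and "the series" means these few. Any claim that something is new, unique, unknown or untested is made for them only; others in the source may bear on it.

Three amides built on one shared core have been tested in a functional assay on HepG2 cells (Homo sapiens) for antiproliferative activity, read by CCK-8 assay, with a stated time of 72 h; a higher number here means a weaker inhibitor, a lower number a stronger inhibitor. Compound 1 `CCc1ccc(C(=O)Nc2cccc(-c3oc4cc(-c5ccc(F)cc5)ccc4c(=O)c3O)c2)cc1` gives 20600 nM. Compound 2 `COc1ccc(C(=O)Nc2cccc(-c3oc4cc(-c5ccc(F)cc5)ccc4c(=O)c3O)c2)c(F)c1` gives 45300 nM, and compound 3 `O=C(Nc1cccc(-c2oc3cc(-c4ccc(F)cc4)ccc3c(=O)c2O)c1)c1ccc(Cl)nc1` gives 4610 nM, the lowest of the three numbers. All steps among them are modest: a 2.2-fold higher number from compound 1 to compound 2 (0.34 log units; beyond the scatter), a 4.5-fold lower number from compound 1 to compound 3 (0.65 log units; beyond the scatter) and a 9.8-fold lower number from compound 2 to compound 3 (0.99 log units; beyond the scatter). Compound 3 thus stands apart from both others, beyond the scatter in each case.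

Compound 4 `N#Cc1ccc(C(=O)Nc2cccc(-c3oc4cc(-c5ccc(F)cc5)ccc4c(=O)c3O)c2)cc1` is the next member, and it differs from compound 3 in one place: 4-cyanophenyl in place of 6-chloropyridin-3-yl on a carbonyl carbon. Among the compounds with values here, none of the measured steps introduces a nitrile, so this change has no direct precedent. The two steps that end at compound 3 show that the group on the carbonyl carbon can shift this assay by a sizeable margin, whereas the step between compounds 1 and 2 shows a smaller one. A 4-cyanophenyl group is neither the chloropyridinyl of compound 3 nor the alkyl- or alkoxy-bearing phenyl of compounds 1 and 2, so a number between those of compound 3 and compound 1 seems the most reasonable expectation, with wide uncertainty. Compound 4 is therefore expected to give 8000 nM, within a range from 2500 nM to 25000 nM. This estimate corresponds to an expected step of a 1.7-fold higher number from compound 3 to compound 4 (0.24 log units; within the scatter), only marginally beyond the scatter.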

Compound 4, half-maximal inhibitory concentration: 7110 nM
Estimate against measurement, compound 4: 1.1-fold (0.05 log units) above; the measured number falls inside the stated range.
By their numbers in this assay, from the lowest: compounds 3 and 4 (each within the scatter of the next); then compound 1; then compound 2.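

In this assay the 4-cyanophenyl group on the carbonyl carbon cannot be told apart from the 6-chloropyridin-3-yl group, as a 1.5-fold higher number from compound 3 to compound 4 (0.19 log units; within the scatter) shows, so a number in this range does not require a ring with a hetero atom or a chlorine. The same group also separates from both substituted phenyl amides, with a 6.4-fold lower number from compound 2 to compound 4 (0.80 log units; beyond the scatter) and a 2.9-fold lower number from compound 1 to compound 4 (0.46 log units; beyond the scatter), and the second of these steps is the cleanest comparison in the set, since only cyano replaces ethyl on an aromatic carbon of an otherwise unchanged ring. Nothing in the material shown explains why these groups give the numbers they do.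

Going by these compounds, whether a carboxylic acid, an amine or a simple chlorine in place of the cyano on this ring would keep the number in the same range remains open. So does whether any group on this carbonyl carbon can take the number well below those of compound 3 and compound 4, which both remain in the micromolar range.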